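A methyl added to a well-tolerated compound

A few compounds are considered here, and "the series" means these few. Any claim that something is new, unique, unknown or untested is made for them only; others in the source may bear on it.

Compound 1 `COc1ccc(-c2nc3ccccn3c2Nc2cc(OC)c(OC)c(OC)c2)cc1O`: 50000 nM
Compound 2 `COc1ccc(-c2nc3cc(C)ccn3c2Nc2cc(OC)c(OC)c(OC)c2)cc1O`: 48000 nM
Compound 3 `COc1ccc(Nc2c(-c3ccc(OC)c(O)c3)nc3cnccn23)cc1`: 62000 nM

These numbers come from an ADME assay on Vero cells (Chlorocebus sabaeus) for cytotoxicity, read by MTT assay; a higher number here means that more compound is tolerated, a lower number that less compound is tolerated. Neither compound 2 nor compound 3 stands apart from compound 1 beyond the usual scatter, so the three form one group on this scale.

Compound 4 `COc1ccc(-c2nc3cccc(C)n3c2Nc2cc(OC)c(OC)c(OC)c2)cc1O`, not yet measured, differs from compound 1 by methyl in place of hydrogen on an aromatic carbon. Its methyl sits next to the ring nitrogen.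

Among the measured compounds shown here, one measured step bears on this change. It is also methyl in place of hydrogen on an aromatic carbon, though at another place on the shared core, and it gave a 1.0-fold lower number from compound 1 to compound 2 (0.02 log units; within the scatter). For the measured compounds named here, no compound carrying a methyl at the new place has been measured, so this guide is only partial. On the strength of compound 2, no step beyond the scatter is expected in this assay. The estimated step is no change at the digits printed from compound 1 to compound 4 (within the scatter). For compound 4 the expected value is 50000 nM, within an estimated range of 28000 nM to 90000 nM.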

Compound 4, concentration lethal to 50% of the cells: 74000 nM
Beside the measured number, compound 4's estimate is 1.5-fold (0.17 log units) below it; the range from low to high includes it.
By their numbers in this assay, from the lowest: compounds 2, 1, 3 and 4 (each within the scatter of the next).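

In this assay, methyl in place of hydrogen on an aromatic carbon next to the ring nitrogen gives a 1.5-fold higher number from compound 1 to compound 4 (0.17 log units; within the scatter) and so stays within the usual scatter at this position as well. Alongside a 1.0-fold lower number from compound 1 to compound 2 (0.02 log units; within the scatter) at another place on the shared core, this means that methyl has now been placed at two positions without a step beyond the scatter, and neither compound goes against that reading. No measurement here offers an explanation for the result.

The compounds shown leave open whether something other than methyl at this same position, such as an amine, a carboxylic acid or a longer chain, would also stay within the scatter. They also leave open whether a methyl at both places together would do so.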